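The compounds below may be only part of what the source reports. "The series", "measured", "known", "first", "only" and "open" are said of these compounds alone.

Measured compounds in a functional assay on MCF7 cells (Homo sapiens) for antiproliferative activity, read by MTT assay, with a stated time of 24 h; a higher number here means a weaker inhibitor, a lower number a stronger inhibitor:
compound 1 `Fc1ccc(C2CC(c3ccccc3)=NN2c2ccc(-c3ccccc3)nn2)cc1` gives 100000 nM
compound 2 `COc1ccc(C2=NN(c3ccc(-c4ccccc4)nn3)C(c3ccc(F)cc3)C2)cc1` gives 20000 nM
compound 3 `COc1ccc(C2=NN(c3ccc(-c4ccccc4)nn3)C(c3ccc(OC)cc3)C2)cc1` gives 100000 nM

The step from compound 1 to compound 2 is methoxy in place of hydrogen on an aromatic carbon, and it brought a 5.0-fold lower number from compound 1 to compound 2 (0.70 log units; beyond the scatter). The change from compound 2 to compound 3 then brought a 5.0-fold higher number from compound 2 to compound 3 (0.70 log units; beyond the scatter), leaving compound 3 level with compound 1. Compound 4 `COc1ccc(C2=NN(c3ccc(-c4ccccc4)nn3)C(c3ccc(OC)cc3OC)C2)cc1` is not yet measured; it differs from compound 3 by methoxy in place of hydrogen on an aromatic carbon. This is the same kind of change as from compound 1 to compound 2, though the place differs: there the methoxy sat para to a large group, here it sits ortho to a large group and meta to a methoxy group. The difference between the two cores is not broken down here. For compound 4 in this assay a step of a 2.0-fold lower number from compound 3 to compound 4 (0.30 log units; within the scatter) is expected, resting on the modest gain seen as a 5.0-fold lower number from compound 1 to compound 2 (0.70 log units; beyond the scatter), tempered by the different place. Compound 4 is therefore estimated at 50000 nM, between 15000 nM and 150000 nM.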

Compound 4, half-maximal inhibitory concentration: 100000 nM
For compound 4 the middle estimate is 2.0-fold (0.30 log units) below the measured one; the range from low to high includes it.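

In this assay, adding a methoxy to the 4-methoxyphenyl group brought no change at the digits printed from compound 3 to compound 4 (within the scatter), while 2,4-dimethoxyphenyl in place of 4-fluorophenyl brought a 5.0-fold higher number from compound 2 to compound 4 (0.70 log units; beyond the scatter). Going by these compounds alone, the gain from adding a methoxy therefore did not carry over from one core to the other at the same size: the same change on two cores in this assay, a 5.0-fold lower number (0.70 log units; beyond the scatter) from compound 1 to compound 2 and no change at the digits printed (within the scatter) from compound 3 to compound 4, 5.0-fold (0.70 log units) apart, beyond the scatter of two such steps This does not show why, since the methoxy also sits in a different place in the two steps, and each core offers only a single pair.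

The compounds shown leave open whether the difference follows the core or the place. They also leave open how an amine, a carboxylic acid or a longer chain on that aromatic ring would read.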